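This account rests on a few compounds, and the source may have more. Where it says the series, first, only, none or still open, it means among the compounds named here.

In a functional assay on L1210 cells (Mus musculus) for cytotoxicity, with a stated time of 48 h (a lower number here means a stronger inhibitor, a higher number a weaker inhibitor), compound 3 `O=C1/C(=C/c2ccc(F)cc2)CCC/C1=C\c1ccc([N+](=O)[O-])cc1` gives 26800 nM, the highest of the three numbers recorded. Compound 1 `O=C1CCCC/C1=C\c1ccccc1[N+](=O)[O-]` gives 23800 nM, and the gap between compound 1 and compound 3 lies within the scatter. Compound 2 `Cc1ccc(/C=C2\CCC/C(=C\c3ccc([N+](=O)[O-])cc3)C2=O)cc1` gives 8160 nM. Going by the values given here, the one measured step in the set, a 3.3-fold higher number from compound 2 to compound 3 (0.52 log units; beyond the scatter), is the only one with a bearing on the present change, since it too exchanges one group for another on an aromatic carbon of the same kind of ring. Compound 4 `O=C1/C(=C/c2ccc(Cl)cc2)CCC/C1=C\c1ccc([N+](=O)[O-])cc1` differs from compound 3 by chloro in place of fluoro on an aromatic carbon. Among the compounds with values here, no measured pair exchanges chloro for fluoro, so the size of this step cannot be read directly from the series; the single recorded step concerned a different pair of groups and was itself modest. The expected step for compound 4 in this assay is therefore a 1.5-fold lower number from compound 3 to compound 4 (0.17 log units; within the scatter), at or inside the scatter, leaning if anything toward a lower number. Compound 4 is estimated at 18000 nM, with a range from 7000 nM to 50000 nM.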

Compound 4, half-maximal inhibitory concentration: 9410 nM
For compound 4 the middle estimate is 1.9-fold (0.28 log units) above the measured one; the measured number falls inside the stated range.
By their numbers in this assay, from the lowest: compounds 2 and 4 (each within the scatter of the next); then compounds 1 and 3 (each within the scatter of the next).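

In this assay the change from 4-fluorophenyl to 4-chlorophenyl is not silent at this position (a 2.8-fold lower number from compound 3 to compound 4 (0.45 log units; beyond the scatter)), so an exchange of one halogen for another on this aromatic carbon is enough to move the number beyond the scatter. Chloro and methyl read alike here (a 1.2-fold higher number from compound 2 to compound 4 (0.06 log units; within the scatter)), which leaves fluoro as the group that stands apart among these three compounds: compound 3 carries the higher number against both compound 2 and compound 4. No measured evidence bears on the reason for this difference.

On these data alone, whether bromo, methoxy, trifluoromethyl or an amine at this position would sit with chloro and methyl or with fluoro remains open. Also open, as far as these compounds go, is whether the fluoro-to-chloro step keeps its size when the nitro group on the second aromatic ring gives way to a nitrile or a carboxylic acid.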